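A few compounds are considered here, and "the series" means these few. Any claim that something is new, unique, unknown or untested is made for them only; others in the source may bear on it.

Going by the values given here, compound 3 `CC(C)(C)c1cnc(-c2nn(Cc3ccccc3F)c3ncccc23)nc1N` gives 709000 nM in a functional assay (aorta) with Oryctolagus cuniculus as the target (a higher number here means a weaker inhibitor, a lower number a stronger inhibitor), the highest of the three numbers measured so far. Compound 1 `Cc1cnc(-c2nn(Cc3ccccc3F)c3ncccc23)nc1N` gives 675000 nM, and the step of a 1.1-fold higher number from compound 1 to compound 3 (0.02 log units; within the scatter) lies within the scatter, so these two cannot be told apart. Compound 2 `CCCCc1cnc(-c2nn(Cc3ccccc3F)c3ncccc23)nc1N` gives 218000 nM, and the step of a 3.3-fold higher number from compound 2 to compound 3 (0.51 log units; beyond the scatter) sets compound 3 apart as the weaker inhibitor of that pair. Compound 4 `Nc1nc(-c2nn(Cc3ccccc3F)c3ncccc23)ncc1C1CCC1` has not yet been measured; it differs from compound 3 by cyclobutyl in place of tert-butyl on an aromatic carbon. Among the compounds with values here, two measured steps bear on this change: a 3.1-fold lower number from compound 1 to compound 2 (0.49 log units; beyond the scatter) and a 3.3-fold higher number from compound 2 to compound 3 (0.51 log units; beyond the scatter), both modest. Neither exchanges one four-carbon group for another of the same size, so the guidance is indirect; the butyl of compound 2 gave a lower number than the tert-butyl of compound 3. A small step is therefore expected in this assay, if any, toward a lower number. Compound 4 is estimated at 500000 nM, with a range from 150000 nM to 1500000 nM. The step of a 1.4-fold lower number from compound 3 to compound 4 (0.15 log units; within the scatter) is expected to stay close to the scatter.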

Compound 4, half-maximal inhibitory concentration: 633000 nM
Compound 4: the middle estimate sits 1.3-fold (0.10 log units) below what was measured; the measured number falls inside the stated range.
By their numbers in this assay, from the lowest: compound 2; then compounds 4, 1 and 3 (each within the scatter of the next).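

In this assay, replacing tert-butyl with cyclobutyl keeps the same count of heavy atoms but adds a ring, and it gives a 1.1-fold lower number from compound 3 to compound 4 (0.05 log units; within the scatter). Replacing methyl with cyclobutyl gives a 1.1-fold lower number from compound 1 to compound 4 (0.03 log units; within the scatter), so neither change can be told from the scatter, and the ring does not separate itself from these two groups at this position. Butyl alone stands apart among the four groups shown, with a 2.9-fold higher number from compound 2 to compound 4 (0.46 log units; beyond the scatter), and nothing measured here explains that difference.

On these data alone, it remains open whether a longer chain such as hexyl, or a butyl chain ending in an amine or a carboxylic acid, would bring the number lower still at this position. Also open, as far as these compounds go, is whether a cyclopentyl ring would match cyclobutyl or butyl.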